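A few compounds are considered here, and "the series" means these few. Any claim that something is new, unique, unknown or untested is made for them only; others in the source may bear on it.

Compound 2, `Nc1nn(C(=O)Nc2ccc(Cc3ccccc3)cc2)c2ccc(Cl)cc12`, is one of two measured members of a short series. In a functional assay on KM12 cells (Homo sapiens) for antiproliferative activity, read by sulforhodamine B assay, with a stated time of 48 h (on this read-out higher numbers stand for weaker inhibition of growth and lower numbers for stronger inhibition of growth), compound 2 reaches only the assay limit of > 100000 nM, a limit rather than a number. Its parent, compound 1, `Nc1nn(C(=O)Nc2ccc(Cc3ccccc3)cc2)c2ccccc12`, likewise gives only the limit of > 100000 nM in this assay. Among the measured compounds shown here, the one step that connects them, a step that the two limits leave unreadable from compound 1 to compound 2, therefore carries no readable size, and the shared limit of > 100000 nM in this assay, at which 2 of the 2 values shown sit, is the whole of what these two values show: neither compound reaches a measurable total growth inhibition.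

Compound 3, `Nc1ccc2c(c1)c(N)nn2C(=O)Nc1ccc(Cc2ccccc2)cc1`, differs from compound 2 in a single place: amino in place of chloro on an aromatic carbon. No measured step tells how such a swap shifts potency here, since the only step shown from compound 1 to compound 2 sits between two limits. With both neighbours at the limit, the expectation for compound 3 in this assay is that it stays near that limit, so the estimated step is a number no higher from compound 2 to compound 3 (the limit leaves the size open). Compound 3 is accordingly estimated at 100000 nM, within a range from 30000 nM to 300000 nM.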

Compound 3, concentration for total growth inhibition: 15100 nM
Compound 3: middle estimate off by 6.6-fold (0.82 log units), on the high side; the measured number lies below the stated range.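

On this carbon of the shared core, the amino group gives the first measurable total growth inhibition in the series in this assay: amino in place of chloro gives an at least 6.6-fold lower number from compound 2 to compound 3 (0.82 log units; beyond the scatter), and amino in place of hydrogen gives an at least 6.6-fold lower number from compound 1 to compound 3 (0.82 log units; beyond the scatter). Where the earlier pair left the effect of a change at this place unreadable, these steps show that the read-out can respond to a change here, at least for the amino group. Both steps give only a smallest possible size, since each starts from a compound at a limit of the assay: the limit of > 100000 nM in this assay, at which 2 of the 3 values shown sit.

The compounds shown leave open whether this shift belongs to the amino group alone, or whether a hydroxyl, a methoxy group, an acetamide or a dimethylamino group at the same place would also bring the number down from the limit. They also leave open the true size of both steps, and whether an amino group on another carbon of the same six-membered ring would do the same.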